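This account rests on a few compounds, and the source may have more. Where it says the series, first, only, none or still open, it means among the compounds named here.

Compound 3 `CC#C[C@H]1CN(S(=O)(=O)c2ccc(N)nc2)CCN1c1ccc(C(C)=O)cc1` stands at a limit on the numbers shown. In an assay on cells (Hepatocyte) for inhibition of glucokinase regulatory protein (Mus musculus), with stated times of 20 min and 40 min (on this read-out lower numbers stand for an effect already at smaller amounts and higher numbers for an effect only at larger amounts of compound), compound 3 gives > 12500 nM, which is a limit of the assay and not a number. Compound 2 `CC#C[C@H]1CN(S(=O)(=O)c2ccc(N)nc2)CCN1c1ccc(S(=O)(=O)Nc2ccccc2)cc1` also gives > 12500 nM in this assay, again a limit. That is the limit of > 12500 nM in this assay, at which 2 of the 3 values shown sit. Compound 1 `CC#C[C@H]1CN(S(=O)(=O)c2ccc(N)nc2)CCN1c1ccc(C(O)(CC#N)C(F)(F)F)cc1`, whose group on the ring carries a trifluoromethyl, a hydroxyl and a nitrile, gives 219 nM in this assay. The steps away from it are an at least 57-fold higher number from compound 1 to compound 2 (1.75 log units; beyond the scatter) and an at least 57-fold higher number from compound 1 to compound 3 (1.75 log units; beyond the scatter), both large, while a step that the two limits leave unreadable from compound 2 to compound 3.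

Compound 4 `CC#C[C@H]1CN(S(=O)(=O)c2ccc(N)nc2)CCN1c1ccc([C@](O)(CO)C(F)(F)F)cc1` differs from compound 3 in one place: 1,2-dihydroxy-1-(trifluoromethyl)ethyl in place of acetyl on an aromatic carbon. The entering group shares a trifluoromethyl and a hydroxyl with the group of compound 1, so the change runs back toward compound 1. The step that bears on it is the large one from compound 1 to compound 3, now read in reverse, and a large fall in this assay is therefore expected, an at least 35-fold lower number from compound 3 to compound 4 (1.55 log units; beyond the scatter). Compound 4 is estimated at 350 nM in this assay, between 100 nM and 2000 nM, because compound 1 gives 219 nM.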

Compound 4, half-maximal effective concentration: 98 nM
Beside the measured number, compound 4's estimate is 3.6-fold (0.55 log units) above it; measured number below the stated range.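

At this place on the ring, para to a large group, 1,2-dihydroxy-1-(trifluoromethyl)ethyl restores a strong effect, with an at least 120-fold lower number from compound 3 to compound 4 (2.10 log units; beyond the scatter) and an at least 120-fold lower number from compound 2 to compound 4 (2.10 log units; beyond the scatter). A nitrile is therefore not required for an effect in this series, since the nitrile-free group of compound 4 also gives a 2.2-fold lower number from compound 1 to compound 4 (0.35 log units; beyond the scatter), a modest step that lies beyond the scatter. Compound 2 and compound 3 each stand at a limit and not at a number: the limit of > 12500 nM in this assay, at which 2 of the 4 values shown sit.

What stays open is which part of the entering group accounts for the gain, the trifluoromethyl or either hydroxyl, and what the opposite arrangement at its stereocentre would give. Going by these compounds, it is also open whether an amine or a carboxylic acid in place of the second hydroxyl would keep the number this low.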